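Chloro in Place of Nitro on a Growth Inhibitor

This account rests on a few compounds, and the source may have more. Where it says the series, first, only, none or still open, it means among the compounds named here.

In a functional assay on DU-145 cells (Homo sapiens) for inhibition, read by trypan blue exclusion, with a stated time of 96 h (a lower number here means a stronger inhibitor of growth, a higher number a weaker inhibitor of growth), compound 1 `Cc1cc(C)cc(/C=C(\C(=O)c2ccc(Cl)cc2)S(=O)(=O)Cc2ccc(Cl)cc2)c1` gives 1000 nM and compound 2 `Cc1ccsc1/C=C(\C(=O)c1ccc([N+](=O)[O-])cc1)S(=O)(=O)Cc1ccc(Cl)cc1` gives 1000 nM as well, so compound 2 stands level with compound 1. These two differ in more than one place, so the pair isolates no single change. Compound 3 `Cc1ccsc1/C=C(\C(=O)c1ccc(Cl)cc1)S(=O)(=O)Cc1ccc(Cl)cc1` differs from compound 2 in one place, with chloro in place of nitro on an aromatic carbon para to a large group chloro in place of nitro on an aromatic carbon and the rest unchanged. Among the measured compounds shown here, no measured pair shows this swap alone. For the measured compounds named here, the only hint is that compound 1 already carries the 4-chlorophenyl and gives 1000 nM in this assay without any nitro. The expected move a 1.3-fold lower number from compound 2 to compound 3 (0.10 log units; within the scatter) is estimated to stay within the scatter of this assay and to have no clear direction. In this assay the estimated value for compound 3 is 800 nM with an expected range from 250 nM to 2500 nM for this compound.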

Compound 3, concentration for 50% growth inhibition: 25000 nM
For compound 3 the middle estimate is 31-fold (1.49 log units) below the measured one; the measured number lies above the stated range.
By their numbers in this assay, from the lowest: compounds 1 and 2 (each within the scatter of the next); then compound 3.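

In this assay, going from 4-nitrophenyl to 4-chlorophenyl gives a 25-fold higher number from compound 2 to compound 3 (1.40 log units; beyond the scatter), so with the 3-methylthiophen-2-yl group in the molecule, chloro cannot stand in for nitro at this position. The 4-chlorophenyl alone does not settle the outcome: compound 1 and compound 3 both carry it, yet 3-methylthiophen-2-yl in place of 3,5-dimethylphenyl gives a 25-fold higher number from compound 1 to compound 3 (1.40 log units; beyond the scatter), so the group at the other end of the molecule counts as well. Nothing measured here explains why either swap has so large an effect.

Going by these compounds, whether an amine or a carboxylic acid at this position would match the nitro or fall to the level of the chloro stays open. So does what a 4-nitrophenyl would do alongside the 3,5-dimethylphenyl group.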